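This account rests on a few compounds, and the source may have more. Where it says the series, first, only, none or still open, it means among the compounds named here.

Compound 1 `O=C(N[C@@H](CCC(=O)N1CCN(c2cccc(NC3=NCCCN3)c2)CC1)C(=O)O)OCc1ccccc1` gives 1.1 nM in a functional assay (muscle tissue) for inhibition, with Homo sapiens as the target (a higher number here means a weaker inhibitor, a lower number a stronger inhibitor), the lowest of the three numbers in hand. Compound 2 `O=C(N[C@@H](CCC(=O)N1CCN(c2cccc(NC3=NCC(O)CN3)c2)CC1)C(=O)O)OCc1ccccc1` gives 3.5 nM, a change of a 3.2-fold higher number from compound 1 to compound 2 (0.50 log units; beyond the scatter). Compound 3 `CC(C)COC(=O)N[C@@H](CCC(=O)N1CCN(c2cccc(NC3=NCC(O)CN3)c2)CC1)C(=O)O` gives 2 nM, and the step of a 1.8-fold lower number from compound 2 to compound 3 (0.24 log units; within the scatter) stays within the scatter. Compound 4 `O=C(NCc1ccccc1)N[C@@H](CCC(=O)N1CCN(c2cccc(NC3=NCCCN3)c2)CC1)C(=O)O` differs from compound 1 by benzylamino in place of benzyloxy on a carbonyl carbon. Going by the values given here, neither measured step touches the carbonyl carbon altered here: one changes a saturated ring carbon, the other the group bound to oxygen, so no direct precedent exists for this exchange. The two measured steps were modest or within the scatter, so compound 4 is expected to shift at most modestly, a 2.0-fold higher number from compound 1 to compound 4 (0.30 log units; within the scatter), toward a somewhat higher number. Compound 4 is therefore estimated at 2.2 nM, in a range of 0.7 nM to 7 nM.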

Compound 4, half-maximal inhibitory concentration: > 10 nM
Compound 4 ended at the assay's limit; the forecaster's own chance of this, stated with the estimate: 0%; at least 4.5-fold (0.65 log units) between middle value and limit.
By their numbers in this assay, from the lowest: compounds 1, 3 and 2 (each within the scatter of the next, the first and the last beyond it). At a limit, above all of these: compound 4.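

In this assay compound 4 stands at a limit, not at a number: the limit of > 10 nM in this assay, at which 1 of the 4 values shown sits. Benzylamino in place of benzyloxy on this carbonyl carbon gives an at least 9.0-fold higher number from compound 1 to compound 4 (0.95 log units; beyond the scatter), a larger step than either earlier one, so this position does not accept every exchange of similar size. The compounds shown do not tell how far the loss extends. They also leave open whether a benzyl(methyl)amino group, without the amide hydrogen, or a phenethyl group, with carbon in place of the linking heteroatom, would behave like benzyloxy or like benzylamino.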